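Ester chain extension on the shared core: compound 1 to compound 3

A few compounds are considered here, and "the series" means these few. Any claim that something is new, unique, unknown or untested is made for them only; others in the source may bear on it.

Among the compounds with values here, compound 1 `C=C(C)CCOC(=O)C1=C(C)NC(C)=C(C(=O)OC)C1c1cccc([N+](=O)[O-])c1` stands as the lowest of the two numbers measured so far in a functional assay on HEK293 cells for antagonist activity at Voltage-dependent L-type calcium channel subunit alpha-1C (Oryctolagus cuniculus), read by FLIPR (a lower number here means a stronger inhibitor, a higher number a weaker inhibitor), giving 23 nM. Compound 2 `CCOC(=O)C1=C(C)NC(C)=C(C(=O)OCc2ccc([N+](=O)[O-])cc2)C1c1cccc([N+](=O)[O-])c1`, the nearest neighbour, gives 130 nM in this assay, a gap that lies beyond the usual scatter. Compound 3 `COC(=O)C1=C(C)NC(C)=C(C(=O)OCCCCc2ccc(OC)cc2)C1c1cccc([N+](=O)[O-])c1` has not yet been measured. It differs from compound 1 in one place: 2-(4-methoxyphenyl)ethyl in place of 1-methylethenyl on a saturated chain carbon, two bonds along the chain from an oxygen next to a carbonyl group. Within the data shown here, no step between two measured compounds isolates this change, so no direct precedent exists for it. Since compound 2 shows that a larger aromatic ester substituent can still be tolerated at 130 nM, a modest weakening, or none beyond the scatter, is expected, with the step of a 1.5-fold higher number from compound 1 to compound 3 (0.18 log units; within the scatter) estimated as the likely outcome. For compound 3 the estimate in this assay is 35 nM, within a range from 10 nM to 120 nM.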

Compound 3, half-maximal inhibitory concentration: 17 nM
Compound 3: the middle estimate sits 2.1-fold (0.31 log units) above what was measured; the measured number falls inside the stated range.
By their numbers in this assay, from the lowest: compounds 3 and 1 (each within the scatter of the next); then compound 2.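

In this assay, 2-(4-methoxyphenyl)ethyl in place of 1-methylethenyl on a saturated chain carbon gives a 1.4-fold lower number from compound 1 to compound 3 (0.13 log units; within the scatter) at this place, a step within the scatter. The entering group has 10 heavy atoms and a six-membered aromatic ring, the leaving group 3 heavy atoms and no ring, so this much added bulk on the chain leaves the number unchanged within the scatter, something no earlier step at this place had shown. Nothing on hand accounts for this result.

Still open, from the compounds shown here alone, is how an amine or a carboxylic acid at the end of this chain would read in this assay. Equally open, going by these compounds, are whether the methoxy group on the ring matters here and how a longer chain would fare.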